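Replacing methoxymethoxy with bromo at the end of a chain

The source may hold more compounds than are shown below. What is called first, only, known or untested is meant among the compounds shown, and "the series" means these compounds.

compound 1 `COc1ccc(/C=C\c2cc(OC)c(OC)c(OC)c2)cc1OCc1ccc(Br)cc1`: 108000 nM
compound 2 `COc1ccccc1/C=C/CCCOc1cc(/C=C\c2cc(OC)c(OC)c(OC)c2)ccc1OC`: 86000 nM
compound 3 `COCOc1ccc(/C=C/CCCOc2cc(/C=C\c3cc(OC)c(OC)c(OC)c3)ccc2OC)cc1`: 7000 nM

In a functional assay on HT-29 cells (Homo sapiens) for inhibition, read by MTT assay, with a stated time of 3 days (a lower number here means a stronger inhibitor, a higher number a weaker inhibitor), compound 3 holds the lowest of the three numbers, and its gaps to compound 1 and compound 2 both lie beyond the scatter. Compound 4 `COc1ccc(/C=C\c2cc(OC)c(OC)c(OC)c2)cc1OCCC/C=C/c1ccc(Br)cc1` has not yet been measured. It keeps the chain of compound 3 and differs at the far aromatic ring: bromo in place of methoxymethoxy on an aromatic carbon. This places bromo in place of methoxymethoxy on an aromatic carbon, para to a large group.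

Among the measured compounds shown here, two measured steps bear on this change. The closer one is a 12-fold lower number from compound 2 to compound 3 (1.09 log units; beyond the scatter), a large step made at the same ring. The other is a 1.3-fold lower number from compound 1 to compound 2 (0.10 log units; within the scatter), which stays within the scatter. The 4-bromophenyl group itself appears only in compound 1, at 108000 nM, and there it is not carried on this chain. For the measured compounds named here, no measured compound combines the two features, so the size of the step remains uncertain. A move back towards higher numbers is expected, probably smaller than the large measured step. The expected step is a 4.0-fold higher number from compound 3 to compound 4 (0.60 log units; beyond the scatter). For compound 4 the estimate is 28000 nM, with an expected range from 7000 nM to 100000 nM.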

Compound 4, half-maximal inhibitory concentration: 11000 nM
Estimate against measurement, compound 4: 2.5-fold (0.41 log units) above; the range from low to high includes it.
By their numbers in this assay, from the lowest: compounds 3 and 4 (each within the scatter of the next); then compounds 2 and 1 (each within the scatter of the next).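

In this assay, bromo in place of methoxymethoxy on an aromatic carbon, para to a large group, gives a 1.6-fold higher number from compound 3 to compound 4 (0.20 log units; within the scatter), so this position does not separate the two groups, although methoxymethoxy has 4 heavy atoms and 2 hydrogen-bond acceptors and bromo has 1 heavy atom and 0 hydrogen-bond acceptors. The 4-bromophenyl group in place of 2-methoxyphenyl gives a 7.8-fold lower number from compound 2 to compound 4 (0.89 log units; beyond the scatter), which shows that the low number reached with compound 3 does not depend on methoxymethoxy alone. The same 4-bromophenyl group also reads very differently according to what carries it, with a 9.8-fold lower number from compound 1 to compound 4 (0.99 log units; beyond the scatter), so the high number of compound 1 did not belong to the bromo-bearing ring as such but went with the smaller of the two groups.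

Nothing given here accounts for these differences. The compounds shown leave open whether a hydroxyl group or an amine on this same aromatic carbon would hold the number near those of compound 3 and compound 4, and whether a shorter or longer chain would keep it there.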